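The source may report more compounds than this note shows. Statements on the series, on what has been measured and on what is new or still open speak of the compounds shown alone.

Two compounds of this study share a five-membered, selenium-containing core and differ in the base attached to it. Compound 1, `[N-]=[N+]=N[C@@H]1C(n2cc(Br)c(=O)[nH]c2=O)[Se][C@H](CO)[C@H]1O`, carries a brominated base, while compound 2, `[N-]=[N+]=N[C@@H]1C(n2ccc(N)nc2=O)[Se][C@H](CO)[C@H]1O`, carries an amino-substituted base. In a functional assay on PC-3 cells (Homo sapiens) for cytotoxicity, read by sulforhodamine B assay (a lower number here means a stronger inhibitor, a higher number a weaker inhibitor), compound 1 reaches only the limit of the assay, reported as > 100000 nM. In this assay, among the compounds with values here, compound 2 gives 75100 nM, the only actual number among the two values shown. The other value, that of compound 1, is a limit of the assay, as noted by the limit of > 100000 nM in this assay, at which 1 of the 2 values shown sits. Compound 2 therefore stands alone as the single measured point, and it is a weak inhibitor.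

The step under consideration leads to compound 3, `Nc1ccn(C2[Se][C@H](CO)[C@@H](O)[C@@H]2O)c(=O)n1`, which keeps the amino-substituted base of compound 2. The change is hydroxy in place of azido on a saturated ring carbon, in words a hydroxy in place of azido on a saturated ring carbon. Within the data shown here, no measured step of this kind exists among the compounds here. Given the weak activity of compound 2 at 75100 nM, a small step toward equal or weaker inhibition is expected. Compound 3 is estimated to give 100000 nM, within a range from 30000 nM to 300000 nM. That estimate corresponds to an expected step of a 1.3-fold higher number from compound 2 to compound 3 (0.12 log units; within the scatter).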

Compound 3, half-maximal inhibitory concentration: 4540 nM
Beside the measured number, compound 3's estimate is 22-fold (1.34 log units) above it; the whole stated range lies above it.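

Until this point the compounds shown differed only in their base, so they said nothing about the saturated ring carbon of the shared core. Within the data shown here, with the amino-substituted base held constant, hydroxy in place of azido at that carbon gives a 17-fold lower number from compound 2 to compound 3 (1.22 log units; beyond the scatter) in this assay, a large step beyond the scatter and the first sign that the group at this position matters for the read-out in these cells. The compounds shown give no measured property that would account for the size of this step.

On these data alone, whether an amine or a fluorine atom on this carbon would give a number closer to that of compound 2 or to that of compound 3 remains open, and a single pair cannot show which feature of the azido-to-hydroxy change carries the effect. Whether the same change would have a similar effect with the brominated base also stays open, as compound 1 offers only a limit of the assay and not a number: the limit of > 100000 nM in this assay, at which 1 of the 3 values shown sits.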